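The source may hold more compounds than are shown below. What is called first, only, known or untested is meant among the compounds shown, and "the series" means these compounds.

In a functional assay on L1210 cells (Mus musculus) for inhibition (a higher number here means a weaker inhibitor, a lower number a stronger inhibitor), compound 1, with structure `CC(=O)OC(C)n1cnc2c(Cl)nc(N)nc21`, gives only a limit, > 500000 nM, and this is the edge of the assay rather than a measured number, as noted in the limit of > 500000 nM in this assay, at which 1 of the 2 values shown sits. Compound 2, with structure `CC(=O)OC(C)n1cnc2c(N)nc(I)nc21`, gives 421000 nM in this assay. Going by the values given here, no single-change step links the two measured compounds, and their two values can only be set side by side. Compound 3, with structure `CC(=O)OC(C)n1cnc2c(Cl)nc(F)nc21`, has not yet been measured. It differs from compound 1 in one place: fluoro in place of amino on an aromatic carbon. The amino leaves and fluoro enters. Compound 1 stands only as a limit, and no move beyond the scatter toward stronger inhibition is foreseen. The expected step in this assay is a step that the limit leaves unreadable from compound 1 to compound 3. Compound 3 is estimated at 600000 nM, expected to fall from 150000 nM to 3000000 nM, with a real chance that this assay again reports only a limit.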

Compound 3, half-maximal inhibitory concentration: 37000 nM
For compound 3 the middle estimate is 16-fold (1.21 log units) above the measured one; measured number outside the range, below it.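

In this assay, the aromatic carbon between two ring nitrogen atoms turns out to be a place where a single change can move the read-out: fluoro in place of amino gives an at least 13-fold lower number from compound 1 to compound 3 (1.13 log units; beyond the scatter). Compound 1 gives only a limit, > 500000 nM, so on its own it showed no more than weak inhibition with no number attached. The full size of the step remains unknown, because one end of it rests on that limit: the limit of > 500000 nM in this assay, at which 1 of the 3 values shown sits.

The compounds shown do not tell whether the lower number comes from the arrival of fluoro or from the departure of amino, a question that a plain hydrogen or a methoxy group on this carbon would bear on. Going by these compounds, it also remains open whether the step would hold if a group such as a methylthio group replaced the chloro group.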